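Swapping a fluorine for a hydroxyl on the anilino ring

A few compounds are considered here, and "the series" means these few. Any claim that something is new, unique, unknown or untested is made for them only; others in the source may bear on it.

Three closely related compounds share one core and differ only in the aryl group attached to a nitrogen. Compound 1 `Fc1cccc(Nc2nc(-c3cccc(F)c3)nc3ccc(F)cc23)c1` gives 49600 nM in a functional assay on U2OS cells (Homo sapiens) for cytotoxicity, read by MTT assay, with a stated time of 48 h (on this read-out higher numbers stand for weaker inhibition and lower numbers for stronger inhibition), which is the highest of the two plain numbers measured. Compound 3 `Fc1cccc(-c2nc(Nc3ccc(Cl)cc3)c3cc(F)ccc3n2)c1` gives 38400 nM, and the step of a 1.3-fold lower number from compound 1 to compound 3 (0.11 log units; within the scatter) stays within the scatter. Compound 2 `Fc1cccc(-c2nc(Nc3ccccc3F)c3cc(F)ccc3n2)c1` reaches only the limit of the assay and is reported as > 50000 nM. Accordingly, the steps of a number no lower from compound 1 to compound 2 (the limit leaves the size open) and an at least 1.3-fold lower number from compound 2 to compound 3 (0.11 log units; that floor lies within the scatter) say little about size, and a value at the limit of > 50000 nM in this assay, at which 1 of the 3 values shown sits, is a limit rather than a number.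

Compound 4 `Oc1cccc(Nc2nc(-c3cccc(F)c3)nc3ccc(F)cc23)c1` is not yet measured. It differs from compound 1 in one place: hydroxy in place of fluoro on an aromatic carbon. The 3-fluorophenyl becomes a 3-hydroxyphenyl on the same nitrogen. Going by the values given here, none of the measured steps makes this exact change; all of them vary the aryl group on that nitrogen and none moves the read-out beyond the scatter. The expectation for compound 4 is therefore a step of a 1.1-fold lower number from compound 1 to compound 4 (0.04 log units; within the scatter), that is, no change beyond the scatter. Compound 4 is estimated at 45000 nM, with a range from 15000 nM to 140000 nM.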

Compound 4, half-maximal inhibitory concentration: 33300 nM
Beside the measured number, compound 4's estimate is 1.4-fold (0.13 log units) above it, within the range that was stated.
By their numbers in this assay, from the lowest: compounds 4, 3 and 1 (each within the scatter of the next). At a limit, above all of these: compound 2.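

Going by these compounds alone, the swap of fluoro for hydroxy on this aromatic carbon is the first change here that keeps the 3-substituted phenyl on the nitrogen and alters only the group it carries, and in this assay it stays within the scatter (a 1.5-fold lower number from compound 1 to compound 4 (0.17 log units; within the scatter)). So a hydroxy, with one hydrogen-bond donor and one acceptor where fluoro has neither, leaves the read-out where the fluoro compound had it, and the same holds against the 4-chlorophenyl compound (a 1.2-fold lower number from compound 3 to compound 4 (0.06 log units; within the scatter)). Compound 2 remains a limit rather than a number, so its step gives only a floor that lies within the scatter (an at least 1.5-fold lower number from compound 2 to compound 4 (0.17 log units; that floor lies within the scatter)), and its size cannot be read: (the limit of > 50000 nM in this assay, at which 1 of the 4 values shown sits).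

The compounds shown leave open whether an amine, a methoxy group or a carboxylic acid on this same aromatic carbon would move the read-out beyond the scatter, since fluoro and hydroxy are the only two groups compared here on an otherwise unchanged compound. They also leave open whether the same swap of fluoro for hydroxy on the other fluorine-bearing carbons of compound 1 would be just as quiet.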